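The source may hold more compounds than are shown below. What is called first, only, known or untested is meant among the compounds shown, and "the series" means these compounds.

Measured so far in a functional assay on the whole organism with Rattus norvegicus as the target; a lower number here means that less compound is needed, a higher number that more compound is needed for the effect:
- compound 1 `CCN(CCNC(=O)c1cc(Cl)c(N)cc1OC)Cc1cccc(Cl)c1`: 0.58 mg/kg
- compound 2 `CCN1CCC(NC(=O)c2cc(Cl)c(NC)cc2OC)C1`: 10 mg/kg
- compound 3 `CCNc1cc(OC)c(C(=O)NC2CCN(Cc3ccccc3)C2)cc1Cl`: 0.1 mg/kg

Of these three, compound 3 has the lowest number, 0.1 mg/kg, and its distance to each of the other two lies beyond the scatter. Compound 4 `COc1cc(N(C)C(=O)C(F)(F)F)c(Cl)cc1C(=O)NC1CCN(Cc2ccccc2)C1` keeps the rest of compound 3 and alters one group: methyl((trifluoromethyl)carbonyl)amino in place of ethylamino on an aromatic carbon. Here methyl((trifluoromethyl)carbonyl)amino stands in place of ethylamino on an aromatic carbon. Among the measured compounds shown here, no two measured compounds differ in one place only, so nothing measured shows the size of this change, and any forecast is uncertain. A moderate rise in the number is expected, with a 3.0-fold higher number from compound 3 to compound 4 (0.48 log units; beyond the scatter) as the estimated step. For compound 4 the expected value is 0.3 mg/kg, with an estimated range of 0.05 mg/kg to 2 mg/kg.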

Compound 4, dose for half-maximal effect: 0.3 mg/kg
Estimate against measurement, compound 4: no gap at the digits printed; the measured number falls inside the stated range.
By their numbers in this assay, from the lowest: compound 3; then compounds 4 and 1 (each within the scatter of the next); then compound 2.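

In this assay, among the compounds shown here, this is the first pair differing in one place, and putting methyl((trifluoromethyl)carbonyl)amino in place of ethylamino gives a 3.0-fold higher number from compound 3 to compound 4 (0.48 log units; beyond the scatter). The aromatic carbon ortho to the chloro group therefore tolerates a swap from 3 heavy atoms and 1 hydrogen-bond donor to 8 heavy atoms and 0 donors, with compound 4 still at 0.3 mg/kg. Nothing measured here explains the rise. Open, from the compounds shown here alone, is how dimethylamino or acetylamino would compare at this carbon, with the rest of compound 3 kept, and so which part of the new group matters.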